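This account rests on a few compounds, and the source may have more. Where it says the series, first, only, none or still open, it means among the compounds named here.

Measured in a functional assay on HepG2 cells (Homo sapiens) for cytotoxicity, read by MTT assay, with a stated time of 72 h; a lower number here means a stronger inhibitor, a higher number a weaker inhibitor:

Compound 1 `Cc1cc(=O)n(-c2cccc(F)c2)nc1C(=O)Nc1ccc(Oc2ncnc3[nH]ccc23)cc1`: 3180 nM
Compound 2 `Cc1cc(=O)n(-c2ccc(Br)cc2F)nc1C(=O)Nc1ccc(Oc2ncnc3[nH]ccc23)cc1`: 3660 nM
Compound 3 `Cc1cc(=O)n(-c2cccc(F)c2)nc1C(=O)Nc1ccc(Oc2ncnc3[nH]ccc23)c(F)c1`: 23100 nM

Compound 1 stands at the lowest of the three numbers, though compound 2 sits within the scatter of it, the step being a 1.2-fold higher number from compound 1 to compound 2 (0.06 log units; within the scatter). Compound 3 lies furthest away, with a 7.3-fold higher number from compound 1 to compound 3 (0.86 log units; beyond the scatter).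

Compound 4 `Cc1cc(=O)n(-c2cccc(F)c2)nc1C(=O)Nc1ccc(Oc2ncnc3c2ccn3C)cc1` differs from compound 1 by methyl in place of hydrogen on an aromatic nitrogen. Neither measured step touches that five-membered ring: the step to compound 2 exchanges the group on the other aromatic nitrogen, and the step to compound 3 adds fluoro on an aromatic carbon of the anilide ring. Among the compounds with values here, there is therefore no direct precedent for this change, and the two known steps show only that one alteration left the number unchanged while another moved it modestly upward. In this assay compound 4 is expected to fall near or somewhat above compound 1, with the step of a 1.9-fold higher number from compound 1 to compound 4 (0.28 log units; within the scatter) carrying wide uncertainty. The estimate for compound 4 is 6000 nM, with a range from 2000 nM to 25000 nM.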

Compound 4, half-maximal inhibitory concentration: > 60000 nM
Compound 4: only a limit was reported; the forecaster's own chance of this, stated with the estimate: 5%; middle value at least 10-fold (1.00 log units) from the limit.
By their numbers in this assay, from the lowest: compounds 1 and 2 (each within the scatter of the next); then compound 3. At a limit, above all of these: compound 4.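

In this assay, methyl in place of hydrogen on an aromatic nitrogen of the five-membered aromatic ring gives an at least 18-fold higher number from compound 1 to compound 4 (1.27 log units; beyond the scatter), the largest of the single changes shown. This reading for compound 4 is a limit and not a number: the limit of > 60000 nM in this assay, at which 1 of the 4 values shown sits. The earlier steps shown here had left this ring untouched, and compound 4 now shows that a single added heavy atom at this nitrogen can move the number further than either earlier change.

The compounds shown leave open whether this step belongs to methyl alone or would also follow from an ethyl group, a longer chain or a chain ending in an amine on the same nitrogen. They also leave open whether methyl here would act in the same way alongside the 4-bromo-2-fluorophenyl group of compound 2 or the added fluoro of compound 3.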